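Taking the (4-fluorophenyl)carbonyl group off compound 3

The compounds below may be only part of what the source reports. "The series", "measured", "known", "first", "only" and "open" are said of these compounds alone.

Compound 1 `COc1ccc(C(=O)ON=C2CC(c3ccc(O)c(OC)c3)N(C)C(c3ccc(O)c(OC)c3)C2)c(OC)c1` gives 52000 nM
Compound 2 `COc1cc(C2CC(=NOC(=O)c3ccc([N+](=O)[O-])cc3)CC(c3ccc(O)c(OC)c3)N2C)ccc1O` gives 82000 nM
Compound 3 `COc1cc(C2CC(=NOC(=O)c3ccc(F)cc3)CC(c3ccc(O)c(OC)c3)N2C)ccc1O` gives 140000 nM

These values come from a functional assay on microsomes from liver (Rattus norvegicus, strain Wistar) for inhibition, read by spectrophotometry, with a stated time of 60 min; on this read-out higher numbers stand for weaker inhibition and lower numbers for stronger inhibition. Compound 3 stands clearly apart from only one of the others, with a 2.7-fold higher number from compound 1 to compound 3 (0.43 log units; beyond the scatter), while a 1.7-fold higher number from compound 2 to compound 3 (0.23 log units; within the scatter) is no real separation.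

Compound 4 `COc1cc(C2CC(=NO)CC(c3ccc(O)c(OC)c3)N2C)ccc1O` has hydrogen in place of (4-fluorophenyl)carbonyl on an oxygen. The measured steps only swap what sits on the carbonyl carbon, and none removes the whole group, so they guide weakly. Those swaps stayed small, with a 1.6-fold higher number from compound 1 to compound 2 (0.20 log units; within the scatter) as the third example. No clear shift is therefore expected in this assay, at most a slight drift toward lower numbers.

The expected change is a 1.6-fold lower number from compound 3 to compound 4 (0.19 log units; within the scatter).

For compound 4 the estimate is 90000 nM, with an expected range of 30000 nM to 250000 nM.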

Compound 4, half-maximal inhibitory concentration: 167000 nM
Compound 4: middle estimate off by 1.9-fold (0.27 log units), on the low side; low and high end bracket the measured number.
By their numbers in this assay, from the lowest: compounds 1, 2, 3 and 4 (each within the scatter of the next, the first and the last beyond it).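

In this assay the whole (4-fluorophenyl)carbonyl group can give way to hydrogen on this oxygen with only a 1.2-fold higher number from compound 3 to compound 4 (0.08 log units; within the scatter) as the result, so here the full group and a bare hydroxy are not told apart. The other two removals are larger but still modest, with a 2.0-fold higher number from compound 2 to compound 4 (0.31 log units; beyond the scatter) and a 3.2-fold higher number from compound 1 to compound 4 (0.51 log units; beyond the scatter) as the steps, so the (2,4-dimethoxyphenyl)carbonyl group is the one that shows the clearest gain over hydrogen. Nothing measured here explains these differences.

Still open, from the compounds shown here alone, is how a small methyl or acetyl group on this oxygen would compare, and whether a chain ending in an amine or a carboxylic acid would move the number further from that of compound 4.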